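Acetamido to Acyl Sulfonamide: Expected Exposure Shift

The source may hold more compounds than are shown below. What is called first, only, known or untested is meant among the compounds shown, and "the series" means these compounds.

Compound 1, `CCCCN(c1nc2c(NC(C)=O)cccc2o1)[C@H](C)c1ccc(-c2ccccc2-c2nnn[nH]2)cc1`, was measured in an ADME assay on the whole organism (Macaca fascicularis) for pharmacokinetics, read by LC-MS, using cassette dosing, at a dose of 1 mg/kg by the oral route (a higher number here means more compound in the circulation at the dose given, a lower number less compound in the circulation), and gives 41.6 ng.h/mL. Within the data shown here, of the two compounds measured so far, compound 1 stands lowest. Among the measured compounds shown here, the only other measured compound, compound 2, `C[C@H](c1ccc(-c2ccccc2-c2nc(=O)o[nH]2)cc1)N(CC1CC1)c1nc2c(C(=O)O)cccc2o1`, gives 11600 ng.h/mL in this assay, a far higher value, but it differs from compound 1 in several places at once, so the two values show only how wide the spread can be, not a single step. Compound 3, `CCCCN(c1nc2c(C(=O)NS(C)(=O)=O)cccc2o1)[C@H](C)c1ccc(-c2ccccc2-c2nnn[nH]2)cc1`, is not yet measured. It differs from compound 1 in one place: (methylsulfonyl)carbamoyl in place of acetamido on an aromatic carbon. For the measured compounds named here, no measured pair isolates this change, so the expectation rests on the large gap to compound 2 and carries wide uncertainty. The step expected from this change is a 4.8-fold higher number from compound 1 to compound 3 (0.68 log units; beyond the scatter), upward and beyond the scatter. Compound 3 is therefore estimated to give 200 ng.h/mL in this assay, with a range from 40 ng.h/mL to 1500 ng.h/mL.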

Compound 3, area under the concentration-time curve: 22.2 ng.h/mL
Compound 3: the middle estimate sits 9.0-fold (0.95 log units) above what was measured; measured number outside the range, below it.
By their numbers in this assay, from the lowest: compounds 3 and 1 (each within the scatter of the next); then compound 2.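

In this assay, (methylsulfonyl)carbamoyl in place of acetamido on this aromatic carbon gives a 1.9-fold lower number from compound 1 to compound 3 (0.27 log units; within the scatter) and so makes no difference that can be told from the usual spread of repeat measurements. Among these compounds, this is the first pair that differs in one place only, and it shows that, on the core of compound 1, this position can carry either group with the read-out staying within that spread. Nothing measured here explains why the two groups give such similar numbers.

On these data alone, it remains open whether a simple amine or a methyl ester on this same aromatic carbon would also stay within the spread of compound 1. Also open, as far as these compounds go, is which of the several structural differences in compound 2 matters most in this assay.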